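Hydroxy in place of bromo on the aromatic ring

The source may report more compounds than this note shows. Statements on the series, on what has been measured and on what is new or still open speak of the compounds shown alone.

Compound 2 `O=C(CSC(=S)N[C@H]1CCOC1=O)Nc1ccc(Br)cc1` is one of three measured analogues sharing a common core. In a functional assay on MCF7 cells (Homo sapiens) for cytotoxicity, read by MTT assay, with a stated time of 72 h (on this read-out lower numbers stand for stronger inhibition and higher numbers for weaker inhibition), compound 2 gives 66500 nM, the higher of the two plain numbers, with compound 1 `O=C(CSC(=S)N[C@H]1CCOC1=O)Nc1ccc(Cl)cc1` nearest at 50300 nM, a step of a 1.3-fold higher number from compound 1 to compound 2 (0.12 log units; within the scatter). Compound 3 `COc1ccc(NC(=O)CSC(=S)N[C@H]2CCOC2=O)cc1` gives only > 128000 nM, which is a limit of the assay and not a number. That value sits at the limit of > 128000 nM in this assay, at which 1 of the 3 values shown sits. The step from compound 2 to compound 3 is an at least 1.9-fold higher number from compound 2 to compound 3 (0.28 log units; that floor lies within the scatter), and the step from compound 1 to compound 3 is an at least 2.5-fold higher number from compound 1 to compound 3 (0.40 log units; beyond the scatter).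

Compound 4 `O=C(CSC(=S)N[C@H]1CCOC1=O)Nc1ccc(O)cc1` is not yet measured; it differs from compound 2 by hydroxy in place of bromo on an aromatic carbon. For the measured compounds named here, the measured steps that bear on it are the two in which methoxy replaced a halogen, both of which ended at the limit, the one from compound 1 at least modest. Compound 4 is therefore expected to give a higher number than compound 2, an expected step of a 2.0-fold higher number from compound 2 to compound 4 (0.29 log units; within the scatter), with a fair chance that only a limit is reported. The estimate for compound 4 is 130000 nM, ranging from 60000 nM to 280000 nM.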

Compound 4, half-maximal inhibitory concentration: > 128000 nM
Compound 4: a limit, no number; the forecaster's own chance of this, stated with the estimate: 55%; the middle value is on the limit's open side.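

In this assay compound 4 gives > 128000 nM, a limit and not a number, so with hydroxy as with methoxy on this carbon the assay returns no plain value, while only the chloro and bromo compounds give numbers: the limit of > 128000 nM in this assay, at which 2 of the 4 values shown sit.

Hydroxy in place of chloro gives an at least 2.5-fold higher number from compound 1 to compound 4 (0.40 log units; beyond the scatter), and hydroxy in place of bromo gives an at least 1.9-fold higher number from compound 2 to compound 4 (0.28 log units; that floor lies within the scatter), so only the comparison with the chloro compound clears the scatter. The step between compound 3 and compound 4 cannot be read, since both values are limits.

The compounds shown leave open whether an amine, a carboxylic acid or a fluoro group on this carbon would give a plain number. They also leave open how far past the limit compound 3 and compound 4 lie.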